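This account rests on a few compounds, and the source may have more. Where it says the series, first, only, none or still open, it means among the compounds named here.

Compound 1 `COc1cc(-c2cc(COCc3cn(Cc4cc(-c5ccccc5)cnc4Cl)nn3)on2)cc(OC)c1OC` gives the higher of the two numbers recorded in a functional assay on A549 cells (Homo sapiens) for cytotoxicity, read by MTT assay, with a stated time of 48 h (a lower number here means a stronger inhibitor, a higher number a weaker inhibitor), where compound 1 gives 112000 nM. Compound 2 `COc1cc(C2=NOC(COCc3cn(Cc4cc(-c5ccc(C)cc5)cnc4Cl)nn3)C2)cc(OC)c1OC` differs from compound 1 in several places at once. In this assay compound 2 gives 11500 nM, a clearly lower number. Compound 3 `COc1cc(-c2cc(COCc3cn(Cc4cc(C)cnc4Cl)nn3)on2)cc(OC)c1OC` has not yet been measured and differs from compound 1 by methyl in place of phenyl on an aromatic carbon. Among the compounds with values here, no measured pair shows this change alone, so the expected step is a 1.3-fold higher number from compound 1 to compound 3 (0.13 log units; within the scatter), probably within the scatter or toward a slightly higher number. Compound 3 is therefore estimated at 150000 nM, with a range from 50000 nM to 450000 nM.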

Compound 3, half-maximal inhibitory concentration: 256000 nM
Beside the measured number, compound 3's estimate is 1.7-fold (0.23 log units) below it; the measured number falls inside the stated range.
By their numbers in this assay, from the lowest: compound 2; then compound 1; then compound 3.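

In this assay, within the data shown here, the first comparison that changes only this aromatic carbon shows that methyl in place of phenyl gives a modest rise in the number (a 2.3-fold higher number from compound 1 to compound 3 (0.36 log units; beyond the scatter)). At this position, the phenyl therefore goes with the stronger result of this single pair, although removing it shifts the number only modestly. Nothing measured here explains the rise. The compounds shown leave open how an amine or a carboxylic acid at this carbon would read. They also leave open whether the same change would give a similar step in compound 2.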